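The source may report more compounds than this note shows. Statements on the series, on what has been measured and on what is new or still open speak of the compounds shown alone.

Measured compounds in an ADME assay on MT4 cells (Homo sapiens) for cytotoxicity, read by MTT assay, with a stated time of 5 days; on this read-out lower numbers stand for higher toxicity in this test and higher numbers for lower toxicity in this test:
compound 1 `CCN(c1ccnc(Nc2ccc(C#N)cc2)n1)c1c(F)cc(-c2ccc(C#N)cc2)cc1F` gives 105000 nM
compound 2 `N#Cc1ccc(Nc2nccc(N(CCCO)c3c(F)cc(-c4ccc(C#N)cc4)cc3F)n2)cc1` gives 68000 nM
compound 3 `N#Cc1ccc(Nc2nccc(N(CC(O)CO)c3c(F)cc(-c4ccc(C#N)cc4)cc3F)n2)cc1` gives 19500 nM

Among these three, compound 1 carries the highest number in this assay. Its nearest neighbour is compound 2, reached by a 1.5-fold lower number from compound 1 to compound 2 (0.19 log units; within the scatter), a step that does not rise above the scatter. The furthest is compound 3, reached by a 5.4-fold lower number from compound 1 to compound 3 (0.73 log units; beyond the scatter); the companion step a 3.5-fold lower number from compound 2 to compound 3 (0.54 log units; beyond the scatter) shows that the second hydroxy accounts for most of that movement.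

Compound 4 `N#Cc1ccc(Nc2nccc(N(CCCF)c3c(F)cc(-c4ccc(C#N)cc4)cc3F)n2)cc1` is not yet measured. It differs from compound 1 by fluoromethyl in place of hydrogen on a saturated chain carbon, two bonds along the chain from a nitrogen on an aromatic ring. The position is the same one that changes in the step from compound 1 to compound 2, where hydroxymethyl enters; here fluoromethyl enters instead, a group that brings no hydrogen-bond donor and no acceptor. Within the data shown here, the only step that bears directly on this place, a 1.5-fold lower number from compound 1 to compound 2 (0.19 log units; within the scatter), stayed within the scatter even with a hydroxy group present, and the larger movements of compound 3 both depend on the additional hydroxy. Nothing in the data points to fluoromethyl doing more than hydroxymethyl did here.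

Compound 4 is therefore expected to sit close to compound 1, with an estimated step of a 1.1-fold lower number from compound 1 to compound 4 (0.04 log units; within the scatter), that is, no step beyond the scatter. The estimated value for compound 4 in this assay is 95000 nM, with a range from 45000 nM to 200000 nM.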

Compound 4, half-maximal cytotoxic concentration: 241000 nM
Beside the measured number, compound 4's estimate is 2.5-fold (0.40 log units) below it; the measured number lies above the stated range.
By their numbers in this assay, from the lowest: compound 3; then compounds 2 and 1 (each within the scatter of the next); then compound 4.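

In this assay, the earlier compounds had shown this position only moving the number down or staying within the scatter, yet fluoromethyl in place of hydrogen on this saturated chain carbon gives a 2.3-fold higher number from compound 1 to compound 4 (0.36 log units; beyond the scatter) and so moves it up, towards lower toxicity in this test. Among these compounds, the atom at the chain end matters more than the earlier steps suggested: fluoro in place of hydroxy alone gives a 3.5-fold higher number from compound 2 to compound 4 (0.55 log units; beyond the scatter) on the same chain, and 2-fluoroethyl in place of 1,2-dihydroxyethyl gives a 12-fold higher number from compound 3 to compound 4 (1.09 log units; beyond the scatter) as the largest step in the set, so the hydroxy-bearing and fluorinated chains now lie on opposite sides of the ethyl compound. Nothing measured here explains why the fluorinated chain carries the higher number.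

The compounds shown leave open whether this upward step belongs to the fluorine itself or would also appear with an unsubstituted propyl chain, a methoxy group or an amine at the chain end. They also leave open whether a longer chain ending in fluorine, or a 3,3-difluoropropyl chain, would extend the step or reverse it.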